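Removing one chloro group from compound 3: notes on compound 4

The compounds below may be only part of what the source reports. "The series", "measured", "known", "first", "only" and "open" are said of these compounds alone.

The shared core here is an aryl ketone bearing a pyridine-derived substituent, and compound 3 `C=CCOc1c(Cl)cc(Cl)cc1C(=O)c1cccnc1` is the member carrying two chloro groups and an allyloxy group. In a functional assay on PC-3 cells (Homo sapiens) for cytotoxicity, read by sulforhodamine B assay, with a stated time of 48 h (a higher number here means a weaker inhibitor, a lower number a stronger inhibitor), compound 3 gives 96000 nM, the highest of the two numbers available. Compound 2 `O=C(c1cccnc1)c1ccccc1O` carries neither chloro nor allyloxy and in this assay gives 33400 nM, a value beyond the scatter below that of compound 3. Compound 1 `C=CCOc1ccc(F)cc1C(=O)c1cccnc1` returns only a limit in this assay, > 100000 nM. That is the limit of > 100000 nM in this assay, at which 1 of the 3 values shown sits.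

Compound 4 `C=CCOc1c(Cl)cccc1C(=O)c1cccnc1` has not yet been measured. It differs from compound 3 in one place: hydrogen in place of chloro on an aromatic carbon. Within the data shown here, no step between two measured compounds isolates this kind of change, so its size has to be judged from the three values alone. Both compounds with the allyloxy group, compound 1 and compound 3, sit at or near the top of the range, whereas compound 2 without it lies lower; on that basis the loss of one chloro group is expected to move the number little, in either direction, and not beyond the scatter. For compound 4 the expected value in this assay is 100000 nM, with a range from 40000 nM to 300000 nM. Expected is thus a step of a 1.0-fold higher number from compound 3 to compound 4 (0.02 log units; within the scatter) in this assay, with a fair chance that only a limit is reported.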

Compound 4, half-maximal inhibitory concentration: > 100000 nM
Compound 4: a limit, no number (the forecaster's own chance of this, stated with the estimate: 45%); the middle value sits exactly at the limit.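

In this assay compound 4 returns > 100000 nM, a limit and not a number. The step for hydrogen in place of chloro at this position, para to an allyloxy group and meta to a chloro group, is an at least 1.0-fold higher number from compound 3 to compound 4 (0.01 log units; that floor lies within the scatter); as only a floor is printed, the step excludes a lower number on this change, while its true size stays unread and may be anything from negligible to large. This is the first step in the series that isolates a single chloro group, and it shows that this chloro group is not needed to keep the number from reaching the limit, which now holds a larger share of the values: the limit of > 100000 nM in this assay, at which 2 of the 4 values shown sit.

The compounds shown leave open whether another group at this position, such as an amine or a carboxylic acid, would bring the number down in this assay. Equally open is what the allyloxy group itself contributes, as no step shown changes that group alone.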